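The source may hold more compounds than are shown below. What is called first, only, known or untested is meant among the compounds shown, and "the series" means these compounds.

Measured so far:
compound 1 `COc1ccc(C[S+]([O-])c2ncccc2C(=O)Nc2ccncc2)cc1`: 2.14 h
compound 2 `COc1cc(C[S+]([O-])c2ncccc2C(=O)Nc2ccncc2)cc(OC)c1OC`: 7.7 h

Both compounds were run in an ADME assay; on this read-out higher numbers stand for a longer-lived compound and lower numbers for a shorter-lived compound. Compound 1 holds the lower of the two numbers; compound 2 sits clearly higher, and the gap between the two is wider than the scatter of repeated measurements. Within the data shown here, the two differ in more than one place, so no single structural step links them, and their values can only be set side by side.

Compound 3 `CCOc1cc(OC)ccc1C[S+]([O-])c1ncccc1C(=O)Nc1ccncc1` is the next compound, and it has not yet been measured. It is derived from compound 1 by one change: ethoxy in place of hydrogen on an aromatic carbon. Among the measured compounds shown here, no step of exactly this kind has been measured here, so the size of the step must be estimated. A small rise in this assay is expected for the step of a 1.4-fold higher number from compound 1 to compound 3 (0.15 log units; within the scatter), though a result within the scatter would not be surprising. Compound 3 is expected to give about 3 h, with a likely range from 1.4 h to 6.5 h.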

Compound 3, half-life: < 0.02 h
Compound 3 ended at the assay's limit; the forecaster's own chance of this, stated with the estimate: 5%; middle value at least 150-fold (2.17 log units) away from the limit.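

In this assay, ethoxy in place of hydrogen on this aromatic carbon, ortho to a large group and meta to a methoxy group, gives an at least 100-fold lower number from compound 1 to compound 3 (2.02 log units; beyond the scatter). This shows that a single change at this position can move the read-out by a large amount, which compounds 1 and 2 could not show, as they differ in more than one place. The figure for compound 3, < 0.02 h, is a limit of the assay and not a number: the limit of < 0.02 h in this assay, at which 1 of the 3 values shown sits.

Going by these compounds, whether a fluorine atom, a hydroxyl group or a longer chain on the same carbon would bring a drop of similar size stays open. The compounds shown also cannot tell what lies behind the drop, or whether it belongs to this position alone.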